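The source may report more compounds than this note shows. Statements on the series, on what has been measured and on what is new or still open speak of the compounds shown alone.

Of the compounds shown here, three built on one shared core have been tested in an ADME assay on HEK293 cells (Homo sapiens) for cytotoxicity, read by resazurin assay, with a stated time of 48 h; a higher number here means that more compound is tolerated, a lower number that less compound is tolerated. Compound 1 `O=S(=O)(Nc1ccc2oc(-c3ccccc3)nc2c1)c1ccccc1O` gives 33000 nM. Compound 3 `Cc1ccc(S(=O)(=O)Nc2ccc3oc(-c4ccccc4)nc3c2)cc1` gives 75000 nM, the highest of the two plain numbers; the third value is not a number. Compound 2 `O=S(=O)(Nc1ccc2oc(-c3ccccc3)nc2c1)c1ccc(O)cc1` reaches only a limit of the assay, > 100000 nM, and so sits at the limit of > 100000 nM in this assay, at which 1 of the 3 values shown sits. The steps between these compounds are a 2.3-fold higher number from compound 1 to compound 3 (0.36 log units; beyond the scatter), an at least 3.0-fold higher number from compound 1 to compound 2 (0.48 log units; beyond the scatter) and an at least 1.3-fold lower number from compound 2 to compound 3 (0.12 log units; that floor lies within the scatter).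

Compound 4 `CCc1ccc(S(=O)(=O)Nc2ccc3oc(-c4ccccc4)nc3c2)cc1` differs from compound 3 by methyl in place of hydrogen on a saturated chain carbon bound to an aromatic carbon, which read one bond further out is methyl to ethyl, or 4-methylphenyl to 4-ethylphenyl. Within the data shown here, none of the measured steps makes this change: each swaps 2-hydroxyphenyl, 4-hydroxyphenyl or 4-methylphenyl on the sulfonyl sulfur, and the one step of comparably small size, an at least 1.3-fold lower number from compound 2 to compound 3 (0.12 log units; that floor lies within the scatter), stays within the scatter. The step expected here is therefore no change at the digits printed from compound 3 to compound 4 (within the scatter). Compound 4 is estimated at 75000 nM, with a range from 35000 nM to 150000 nM.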

Compound 4, half-maximal cytotoxic concentration: 81000 nM
For compound 4 the middle estimate is 1.1-fold (0.03 log units) below the measured one; measured number inside the range.
By their numbers in this assay, from the lowest: compound 1; then compounds 3 and 4 (each within the scatter of the next). At a limit, above all of these: compound 2.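

In this assay, the change from 4-methylphenyl to 4-ethylphenyl gives a 1.1-fold higher number from compound 3 to compound 4 (0.03 log units; within the scatter), so this added methyl on the saturated chain carbon leaves compound 3 and compound 4 indistinguishable. The longer chain also keeps the separation from the 2-hydroxyphenyl compound, with a 2.5-fold higher number from compound 1 to compound 4 (0.39 log units; beyond the scatter), just as the methyl-bearing compound did. Against the 4-hydroxyphenyl compound, the comparison gives only an at least 1.2-fold lower number from compound 2 to compound 4 (0.09 log units; that floor lies within the scatter), and the value for compound 2 is a limit, not a number: the limit of > 100000 nM in this assay, at which 1 of the 4 values shown sits.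

As far as these compounds go, it remains open whether a longer chain such as propyl would stay within the scatter of these two compounds. From the compounds shown here alone, it is also open whether an amine or a carboxylic acid in place of the ethyl group would shift the tolerated concentration clearly in either direction.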